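The compounds below may be only part of what the source reports. "The series", "measured", "known", "first", "only" and "open" are said of these compounds alone.

Compound 2 `O=C(Nc1ccc(Cl)cc1)NS(=O)(=O)c1cc2ccccc2o1` gives 84% in a functional assay on the whole organism (Mus musculus) for inhibition, at a dose of 150 mg/kg by the oral route (a lower number here means less inhibition, a higher number more inhibition at the dose given (going by the name of the read-out)), the highest of the three numbers in hand; compound 1 `Cc1cccc2cc(S(=O)(=O)NC(=O)Nc3ccc(Cl)cc3)oc12` gives 21% and compound 3 `Cc1ccc2oc(S(=O)(=O)NC(=O)Nc3ccc(Cl)cc3)cc2c1` gives 6% in this assay. Compound 4 `O=C(Nc1ccc(Cl)cc1)NS(=O)(=O)c1cc2cccc(Br)c2o1` differs from compound 2 by bromo in place of hydrogen on an aromatic carbon. Within the data shown here, two measured steps bear on this change: a number 63 percentage points higher from compound 1 to compound 2 (beyond the scatter), and a number 78 percentage points lower from compound 2 to compound 3 (beyond the scatter). Both steps show that adding a group to the six-membered aromatic ring of carbon only in the core of compound 2 lowers inhibition far beyond the scatter, and the methyl of compound 1 sits at the same place as the bromo of compound 4. A large fall is therefore expected. Compound 4 is estimated at 30%, with a range of 5% to 70%, an expected step of a number 54 percentage points lower from compound 2 to compound 4 (beyond the scatter).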

Compound 4, a percentage reported as inhibition, in the whole organism at one dose (the size of the read-out at that dose, not a potency): 18%
Compound 4: the middle estimate sits 12 percentage points above what was measured; the measured number falls inside the stated range.
By their numbers in this assay, from the lowest: compound 3; then compounds 4 and 1 (each within the scatter of the next); then compound 2.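

In this assay, the loss seen with methyl at this place is not confined to that group, since bromo gives a number 66 percentage points lower from compound 2 to compound 4 (beyond the scatter). Exchanging one group for the other gives a number 3 percentage points lower from compound 1 to compound 4 (within the scatter), so this read-out does not separate bromo from methyl here. Nothing measured on hand explains the loss.

The compounds shown leave open whether an amine or a hydroxyl group at this place would also lower inhibition. They also leave open whether bromo at the place of the methyl of compound 3 would behave like that methyl.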